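Moving a hydroxyl group around one ring of a pyridine triad

A few compounds are considered here, and "the series" means these few. Any claim that something is new, unique, unknown or untested is made for them only; others in the source may bear on it.

Of the compounds shown here, three have been measured in an assay on isolated protein for inhibition of DNA topoisomerase 1 (Homo sapiens), with a stated time of 30 min, tested at 100 uM; on this read-out higher numbers stand for a stronger effect at the one concentration tested and lower numbers for a weaker effect. Compound 1 `Oc1ccc(-c2cc(-c3cccs3)cc(-c3cccc(O)c3)n2)cc1` gives 85.7%. Compound 2 `Oc1ccc(-c2cc(-c3ccoc3)cc(-c3cccc(O)c3)n2)cc1` gives 37.4%, and compound 3 `Oc1cccc(-c2cc(-c3ccccn3)cc(-c3ccccc3O)n2)c1` gives 35.4%. Compound 3 therefore has the lowest number of the three, though its value and that of compound 2 lie within the scatter of each other, while compound 1 stands well above both.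

Compound 4 `Oc1ccc(-c2cc(-c3ccccn3)cc(-c3cccc(O)c3)n2)cc1` has not yet been measured. It differs from compound 3 in one place: 4-hydroxyphenyl in place of 2-hydroxyphenyl on an aromatic carbon. Among the compounds with values here, the only measured step, a number 48.3 percentage points lower from compound 1 to compound 2 (beyond the scatter), concerns a different substituent on the shared core and does not bear directly on swapping one hydroxyphenyl group for another. Compound 4 shares its 4-hydroxyphenyl and 3-hydroxyphenyl groups with compound 1 and compound 2, whose values spread widely, so the pyridin-2-yl group of compound 4 leaves its level uncertain.

Within the data shown here, with no directly relevant step, a modest rise is expected, giving a number 9.6 percentage points higher from compound 3 to compound 4 (within the scatter). Compound 4 is estimated at 45% in this assay, with a range from 20% to 75%.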

Compound 4, a percentage reported as inhibition, at one concentration (the size of the read-out at that concentration, not a potency): 2.4%
Compound 4: the middle estimate sits 42.6 percentage points above what was measured; the whole stated range lies above it.
By their numbers in this assay, from the lowest: compound 4; then compounds 3 and 2 (each within the scatter of the next); then compound 1.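

In this assay, the hydroxyl's location on this ring matters, even though 2-hydroxyphenyl and 4-hydroxyphenyl have the same atoms and the same counts of donors and acceptors: the change at this carbon next to the ring nitrogen gives a clear drop (a number 33 percentage points lower from compound 3 to compound 4 (beyond the scatter)). The result also adds pyridin-2-yl to the comparison of the third ring, which falls well short of both furan-3-yl (a number 35 percentage points lower from compound 2 to compound 4 (beyond the scatter)) and thiophen-2-yl (a number 83.3 percentage points lower from compound 1 to compound 4 (beyond the scatter)) while the two hydroxyphenyl groups stay the same. Nothing available explains either drop.

Still open, from the compounds shown here alone, is whether the same hydroxyl move would cost as much with thiophen-2-yl on the shared core. Going by these compounds, it is also open whether this position needs a hydroxyl at all, which a 4-methoxyphenyl or 4-aminophenyl group there could test.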